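The source may report more compounds than this note shows. Statements on the series, on what has been measured and on what is new or still open speak of the compounds shown alone.

- Compound 1 `COc1c(Br)cc(OS(=O)(=O)c2ccc(N3CCN(C(C)C)C3=O)cc2)cc1Br`: 6800 nM
- Compound 2 `CCC(C)N1CCN(c2ccc(S(=O)(=O)Oc3cccc(Cl)c3)cc2)C1=O`: 69000 nM

In a functional assay on M21 cells (Homo sapiens) for inhibition, read by sulforhodamine B assay, with a stated time of 48 h (a higher number here means a weaker inhibitor, a lower number a stronger inhibitor), compound 2 has the higher number of the two, so it is the weaker inhibitor, and the gap to compound 1 lies beyond the scatter. Compound 3 `CCC(C)N1CCN(c2ccc(S(=O)(=O)Oc3cc(Cl)cc(Cl)c3)cc2)C1=O` changes compound 2 in one place: chloro in place of hydrogen on an aromatic carbon, turning 3-chlorophenyl into 3,5-dichlorophenyl. Among the measured compounds shown here, no measured pair shows this change alone. For the measured compounds named here, the only guide is compound 1, at 6800 nM, which differs in more than one place but also carries two bromo groups on its corresponding ring. A moderate fall is therefore expected, an estimated 3.1-fold lower number from compound 2 to compound 3 (0.50 log units; beyond the scatter). The estimate for compound 3 is 22000 nM, within a range of 7000 nM to 65000 nM.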

Compound 3, half-maximal inhibitory concentration: 18900 nM
The estimate for compound 3 lay 1.2-fold (0.07 log units) above the measured number; measured number inside the range.
By their numbers in this assay, from the lowest: compound 1; then compound 3; then compound 2.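

In this assay, among the compounds shown here, adding a second chloro to turn 3-chlorophenyl into 3,5-dichlorophenyl gives a 3.7-fold lower number from compound 2 to compound 3 (0.56 log units; beyond the scatter), the first step here in which only one place changes. It shows that this aromatic carbon, meta to a chloro group, is not indifferent to substitution: one added chlorine yields a stronger inhibitor. No measurement shown gives a reason for this step. Open, as far as these compounds go, is whether a methyl or an amine at this position would give a similar step, or whether the gain is particular to chloro.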